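Forecast for an azetidinyl ether in the Sgk1 assay

A few compounds are considered here, and "the series" means these few. Any claim that something is new, unique, unknown or untested is made for them only; others in the source may bear on it.

Compound 3 `Cc1n[nH]c2nc(-c3ccc(NS(=O)(=O)c4cc(Cl)ccc4F)cc3)nc(OCCC(=O)N(C)C)c12` is the lower of the two numbers reported in an assay for inhibition of serine/threonine-protein kinase Sgk1 (Homo sapiens), with stated times of 30 min and 60 min, in the presence of a further agent that is not named here; on this read-out lower numbers stand for stronger inhibition and higher numbers for weaker inhibition: compound 3 gives 15 nM. Compound 1 `CC(C)NC(=O)c1cc(-c2ccc(NS(=O)(=O)c3cccc(Cl)c3Cl)cc2)nc2[nH]ncc12` sits higher, since compound 1 gives 68 nM. Compound 2 `NCCNC(=O)c1cc(-c2ccc(NS(=O)(=O)c3cccc(Cl)c3Cl)cc2)nc2[nH]ncc12` reaches only the limit of this assay, where compound 2 gives < 1 nM; it is a limit rather than a number (the limit of < 1 nM in this assay, at which 1 of the 3 values shown sits).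

The step now followed leads to compound 4 `Cc1n[nH]c2nc(-c3ccc(NS(=O)(=O)c4cc(Cl)ccc4F)cc3)nc(OCC3CN(C(C)C)C3)c12`, which differs from compound 3 as follows: 1-isopropylazetidin-3-yl in place of (dimethylcarbamoyl)methyl on a saturated chain carbon bound to an oxygen on an aromatic ring. Among the measured compounds shown here, no measured pair carries this particular exchange, and none shares the core of compound 3 with a second partner. For the measured compounds named here, the single measured step, an at least 68-fold lower number from compound 1 to compound 2 (1.83 log units; beyond the scatter), concerns the group on an amide-type nitrogen of a different core, where 2-aminoethyl replaced isopropyl and the number fell sharply. The change from compound 3 to compound 4 likewise introduces a nitrogen-bearing ring in place of a dimethylcarbamoyl chain, but on an oxygen-linked side chain, so the measured step bears only loosely on it.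

On that basis compound 4 is expected to improve on compound 3 by a moderate margin, an estimated 3.0-fold lower number from compound 3 to compound 4 (0.48 log units; beyond the scatter). The estimated value for compound 4 is 5 nM, expected between 1 nM and 30 nM.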

Compound 4, half-maximal inhibitory concentration: 1 nM
Beside the measured number, compound 4's estimate is 5.0-fold (0.70 log units) above it, within the range that was stated.
By their numbers in this assay, from the lowest: compound 4; then compound 3; then compound 1.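

Among the compounds shown here, the change gives a 15-fold lower number from compound 3 to compound 4 (1.18 log units; beyond the scatter) in this assay, so the group on a saturated chain carbon bound to an oxygen on an aromatic ring is a place where this number responds strongly, something no earlier pair could show on this core. The step also comes with the counts of hydrogen-bond donors and acceptors unchanged between the leaving and entering groups, so those counts do not track it, and it replaces an open chain with a carbonyl by a four-membered ring with a nitrogen. It resembles an at least 68-fold lower number from compound 1 to compound 2 (1.83 log units; beyond the scatter) only in that a nitrogen-bearing group enters, on a different core and at a different place, and compound 2 in that step carries a limit, not a number: the limit of < 1 nM in this assay, at which 1 of the 4 values shown sits.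

Which part of the entering group goes with the step stays open, since the ring, its isopropyl and its nitrogen all arrive together, and an azetidine without the isopropyl, a pyrrolidine or an open-chain dimethylamino group would separate them. Whether the same exchange would carry over to the core of compound 1 is also left open.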